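Saturating the terminal vinyl of a polyacetylenic hydroxyketone

A few compounds are considered here, and "the series" means these few. Any claim that something is new, unique, unknown or untested is made for them only; others in the source may bear on it.

Compounds measured so far:
compound 1, `C=CCCCCCC#CC#CCO`, 9.56 ug/mL
compound 2, `C=CCCCCCC#CC#CC(O)CC(C)=O`, 3.74 ug/mL
compound 3, `CCCCCCCC#CC#CCOCC(=O)O`, 7.97 ug/mL

In a functional assay on SK-MEL-2 cells (Homo sapiens) for cytotoxicity (a higher number here means that more compound is needed for the effect, a lower number that less compound is needed), compound 2 gives the lowest of the three numbers. Its nearest neighbour is compound 3, whose value 7.97 ug/mL lies beyond the scatter above it, and the furthest is compound 1, with 9.56 ug/mL. Among the measured compounds shown here, the only single-point step among the measured compounds, a 2.6-fold lower number from compound 1 to compound 2 (0.41 log units; beyond the scatter), concerns a different part of the chain. Compound 4, `CCCCCCCC#CC#CC(O)CC(C)=O`, differs from compound 2 by ethyl in place of vinyl on a saturated chain carbon, five bonds along the chain from a triple-bonded carbon. For the measured compounds named here, no measured step bears directly on this change. Compound 1 and compound 3 differ in this place and elsewhere, and their values in this assay lie within the scatter of each other, so no direction is indicated. Compound 4 is therefore expected to show a 1.0-fold higher number from compound 2 to compound 4 (0.01 log units; within the scatter), a step that stays within the scatter. The estimate for compound 4 is 3.8 ug/mL, with a range from 2 ug/mL to 7.5 ug/mL.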

Compound 4, concentration for half-maximal effect: 1.4 ug/mL
Compound 4: middle estimate off by 2.7-fold (0.43 log units), on the high side; measured number below the stated range.
By their numbers in this assay, from the lowest: compound 4; then compound 2; then compounds 3 and 1 (each within the scatter of the next).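

In this assay, among the compounds shown here, this place on the chain, on which no measured step had borne directly, proves able to shift the number: ethyl in place of vinyl gives a 2.7-fold lower number from compound 2 to compound 4 (0.43 log units; beyond the scatter). Together with a 2.6-fold lower number from compound 1 to compound 2 (0.41 log units; beyond the scatter), which concerns a different part of the chain, this gives two separate single-place changes that each lower the number beyond the scatter. Nothing available explains why this exchange has that result.

The compounds shown leave open whether a longer chain, such as propyl or butyl in place of ethyl, or a carboxylic acid at this place would lower the number further or raise it again. As far as these compounds go, it also remains open whether the same exchange would have a similar result in compound 1, which carries hydrogen in place of 2-oxopropyl.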